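Butyl in Place of Phenyl: What to Expect

The source may hold more compounds than are shown below. What is called first, only, known or untested is meant among the compounds shown, and "the series" means these compounds.

Three compounds share one core and differ only in the group on an oxygen next to a carbonyl group. In a functional assay on HT-29 cells (Homo sapiens) for cytotoxicity, read by MTT assay, with a stated time of 72 h (a higher number here means that more compound is tolerated, a lower number that less compound is tolerated), compound 1 `C=CCOC(=O)Nc1ccc([Se]C#N)cc1` gives 72800 nM, compound 2 `CCOC(=O)Nc1ccc([Se]C#N)cc1` gives 66600 nM, and compound 3 `N#C[Se]c1ccc(NC(=O)Oc2ccccc2)cc1` gives 71700 nM. Compound 3 has the second highest of the three numbers, yet every gap among them is within the scatter. Compound 4 `CCCCOC(=O)Nc1ccc([Se]C#N)cc1` carries butyl in place of phenyl on an oxygen next to a carbonyl group. Among the measured compounds shown here, the steps that bear on this change all alter the group on that same oxygen: a 1.0-fold lower number from compound 1 to compound 3 (0.01 log units; within the scatter), a 1.1-fold higher number from compound 2 to compound 3 (0.03 log units; within the scatter) and a 1.1-fold lower number from compound 1 to compound 2 (0.04 log units; within the scatter). All three stayed within the scatter, so for compound 4 no step beyond the scatter is expected in this assay in either direction, and a 1.0-fold lower number from compound 3 to compound 4 (0.01 log units; within the scatter) is the expected outcome. Compound 4 is therefore estimated at 70000 nM, with a range from 40000 nM to 125000 nM.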

Compound 4, concentration lethal to 50% of the cells: 63700 nM
Compound 4: the middle estimate sits 1.1-fold (0.04 log units) above what was measured; the measured number falls inside the stated range.
By their numbers in this assay, from the lowest: compounds 4, 2, 3 and 1 (each within the scatter of the next).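

In this assay, a butyl chain with no ring on this oxygen stays level with the phenyl ring: the change gives a 1.1-fold lower number from compound 3 to compound 4 (0.05 log units; within the scatter). Butyl also stays within the scatter of the shorter ethyl, with a 1.0-fold lower number from compound 2 to compound 4 (0.02 log units; within the scatter), and of allyl with its double bond, with a 1.1-fold lower number from compound 1 to compound 4 (0.06 log units; within the scatter), so neither ring, chain length nor double bond separates these four compounds. No measurement shown offers an explanation for this flat result. On these data alone, whether an amine or a carboxylic acid on the group at this oxygen, or a much longer chain, would move the number beyond the scatter remains open.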